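This account rests on a few compounds, and the source may have more. Where it says the series, first, only, none or still open, it means among the compounds named here.

Working notes, series read in a functional assay on MCF7 cells (Homo sapiens) for antiproliferative activity, read by MTT assay, with a stated time of 72 h; on this read-out higher numbers stand for weaker inhibition and lower numbers for stronger inhibition:
- compound 1 `CCn1cc(C(CC)(CC)c2ccc(C#CC(O)(CC)CC)c(C)c2)cc1C(=O)NCC(=O)OC`: 26500 nM
- compound 2 `CCn1cc(C(CC)(CC)c2ccc(C#CC(O)(CC)CC)c(C)c2)cc1C(=O)NCCN(C)C`: 13400 nM
- compound 3 `CCn1cc(C(CC)(CC)c2ccc(C#CC(O)(CC)CC)c(C)c2)cc1C(=O)NCCC(=O)O`: 30600 nM

Compound 3 sits at the weak end of this small set, level with one neighbour and apart from the other. The nearest step is a 1.2-fold higher number from compound 1 to compound 3 (0.06 log units; within the scatter). The furthest is a 2.3-fold higher number from compound 2 to compound 3 (0.36 log units; beyond the scatter).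

Compound 4 `CCn1cc(C(CC)(CC)c2ccc(C#CC(O)(CC)CC)c(C)c2)cc1C(=O)N[C@@H](C(=O)O)C(C)C` carries 1-carboxy-2-methylpropyl in place of 2-carboxyethyl on an amide-type nitrogen.

Within the data shown here, the steps that bear on this change are those made on the same amide side chain. Besides the two above, there is a 2.0-fold lower number from compound 1 to compound 2 (0.30 log units; within the scatter). These steps are small, and only one passes the scatter, modestly. None of them tests a branched chain or a defined stereocentre, so the evidence is indirect. A shift beyond the scatter is therefore not expected, and no direction is favoured.

The estimated step is a 1.2-fold lower number from compound 3 to compound 4 (0.09 log units; within the scatter). In this assay compound 4 is estimated at 25000 nM, with an expected range of 10000 nM to 55000 nM.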

Compound 4, half-maximal inhibitory concentration: 18000 nM
For compound 4 the middle estimate is 1.4-fold (0.14 log units) above the measured one; the range from low to high includes it.
By their numbers in this assay, from the lowest: compounds 2, 4, 1 and 3 (each within the scatter of the next, the first and the last beyond it).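

In this assay, 1-carboxy-2-methylpropyl, with its defined stereocentre, stands in place of 2-carboxyethyl on the amide-type nitrogen at a 1.7-fold lower number from compound 3 to compound 4 (0.23 log units; within the scatter) and so gives the set a branched side chain without a step beyond the scatter. Against the other two side chains, the readings are a 1.3-fold higher number from compound 2 to compound 4 (0.13 log units; within the scatter) and a 1.5-fold lower number from compound 1 to compound 4 (0.17 log units; within the scatter) and place compound 4 within the scatter of all three others, although compound 2 and compound 3 stand apart from each other. No measurement on hand offers a cause for these numbers.

Still open, from the compounds shown here alone, is whether the opposite configuration at the stereocentre would give a different number. Also open, going by these compounds, is whether a phenyl group on the side chain, or a longer chain ending in a carboxylic acid, would move the number beyond the scatter.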